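A few compounds are considered here, and "the series" means these few. Any claim that something is new, unique, unknown or untested is made for them only; others in the source may bear on it.

Measured so far:
Compound 1 `Nc1scc(CN2CCN(c3ccc(Cl)c(C(F)(F)F)c3)CC2)c1C(=O)c1ccc(Cl)cc1` gives -60%.
Compound 2 `Nc1scc(CN2CCC(c3ccc(Cl)cc3)CC2)c1C(=O)c1ccc(Cl)cc1` gives -61%.

Both were tested in a functional assay on CHO cells with adenosine receptor A1 (Homo sapiens) as the target, read by cAMP accumulation and immunoassay, with a stated time of 6 min, tested at 10 uM; a lower number here means a stronger effect, a higher number a weaker effect of the compound at the concentration tested. Compound 1 has the higher of the two numbers, but its gap to compound 2 lies within the scatter, so the two cannot be told apart. Going by the values given here, no step between measured compounds has been worked out. Compound 3 `Nc1scc(CN2CCN(c3cc(F)ccc3F)CC2)c1C(=O)c1ccc(Cl)cc1` is not yet measured; it differs from compound 1 by 2,5-difluorophenyl in place of 4-chloro-3-(trifluoromethyl)phenyl on an amine nitrogen in a ring. Among the compounds with values here, with no measured step to lean on, a small shift toward a weaker effect, or none beyond the scatter, is expected, as a number 10 percentage points higher from compound 1 to compound 3 (within the scatter). Compound 3 is estimated at -50%, between -75% and -20%.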

Compound 3, a percentage reported as activity, at one concentration (the size of the read-out at that concentration, not a potency): -80%
Beside the measured number, compound 3's estimate is 30 percentage points above it; measured number outside the range, below it.
By their numbers in this assay, from the lowest: compound 3; then compounds 2 and 1 (each within the scatter of the next).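

Changing the aryl group on the amine nitrogen of the ring does move the read-out in this assay: 2,5-difluorophenyl in place of 4-chloro-3-(trifluoromethyl)phenyl gives a number 20 percentage points lower from compound 1 to compound 3 (beyond the scatter) and so a stronger effect. Chlorine and trifluoromethyl leave and two fluorines enter in this single change, so the compounds cannot separate the part each one plays. Nothing measured here explains the step. Still open, from the compounds shown here alone, is how a single fluorine at this position would compare. A methoxy group or an amine on the same phenyl ring is equally untested in the compounds shown.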